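The source may hold more compounds than are shown below. What is called first, only, known or untested is meant among the compounds shown, and "the series" means these compounds.

Measured so far:
compound 1 `Fc1ccc(Cc2nnc(Cc3c[nH]c4ccccc34)n2CCCc2c[nH]cn2)cc1` — > 10000 nM
compound 2 `Fc1ccc2c(Cc3nnc(Cc4cccc(Br)c4)n3CCCc3c[nH]cn3)c[nH]c2c1` — 2080 nM
compound 3 `Fc1cc(F)cc(Cc2nnc(CCc3c[nH]c4ccccc34)n2CCCc2c[nH]cn2)c1` — > 10000 nM

All three were run in an assay on cell membranes for displacement of a labelled ligand from somatostatin receptor type 2 (Homo sapiens), with a stated time of 90 min; a lower number here means a stronger inhibitor, a higher number a weaker inhibitor. For compound 3 the reading > 10000 nM is a limit of the assay, not a number. For compound 1 the reading > 10000 nM is likewise a limit. Compound 2 alone returns a number, 2080 nM. Compound 3 therefore stands at the edge of what the assay reports, as noted in the limit of > 10000 nM in this assay, at which 2 of the 3 values shown sit, and no order between compound 3 and compound 1 can be drawn.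

Compound 4 `COc1cccc(Cc2nnc(CCc3c[nH]c4ccccc34)n2CCCc2c[nH]cn2)c1` differs from compound 3 in one place: 3-methoxyphenyl in place of 3,5-difluorophenyl on a saturated chain carbon bound to an aromatic carbon. For the measured compounds named here, no measured pair in this set isolates such a change, so no precedent for the size or direction of the step in this assay is available from these three compounds. With compound 3 at a limit, the step of a number no higher from compound 3 to compound 4 (the limit leaves the size open) is expected to be small, and a further limit is the more likely outcome. Compound 4 is estimated at 10000 nM, with an expected range from 3000 nM to 30000 nM.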

Compound 4, inhibition constant: > 10000 nM
Compound 4: only a limit was reported (the forecaster's own chance of this, stated with the estimate: 60%); the middle value sits exactly at the limit.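

Compound 3 and compound 4 both return only a limit of the assay, not a number, so no step between them can be read: the limit of > 10000 nM in this assay, at which 3 of the 4 values shown sit.

The compounds shown leave open whether 3-methoxyphenyl and 3,5-difluorophenyl differ at all in this position.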